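Working notes on two measured esters and one new compound

A few compounds are considered here, and "the series" means these few. Any claim that something is new, unique, unknown or untested is made for them only; others in the source may bear on it.

Measured so far:
compound 1 `O=C(OC[C@H]1O[C@@H](O[C@@H](C(=O)O)c2ccccc2)[C@H](O)[C@@H](O)[C@@H]1O)c1ccccc1` — > 10000 nM
compound 2 `CCOC(=O)[C@H](O[C@@H]1O[C@H](CO[C@@H]2O[C@H](CO)[C@@H](O)[C@H](O)[C@H]2O)[C@@H](O)[C@H](O)[C@H]1O)c1ccccc1` — > 10000 nM

In an ADME assay on Bel-7402 cells (Homo sapiens) for cytotoxicity (on this read-out lower numbers stand for stronger inhibition and higher numbers for weaker inhibition), compound 1 gives > 10000 nM, which is a limit of the assay and not a number. Compound 2 gives > 10000 nM in this assay, likewise a limit. Compound 1 therefore stands where every value shown stands: the limit of > 10000 nM in this assay, at which 2 of the 2 values shown sit. Among the measured compounds shown here, no two measured compounds differ in only one place, so no measured step is available to follow.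

Compound 3 `COc1cc(CO)ccc1O[C@@H]1O[C@H](COC(=O)c2ccccc2)[C@@H](O)[C@H](O)[C@H]1O` is not yet measured. It departs from compound 1 by 4-(hydroxymethyl)-2-methoxyphenyl in place of carboxy(phenyl)methyl on an oxygen on a saturated carbon. Because both measured values sit at the limit (the limit of > 10000 nM in this assay, at which 2 of the 2 values shown sit), no direction can be read from the data, and for compound 3 no step beyond the scatter is expected in this assay. The expected step is a step that the limit leaves unreadable from compound 1 to compound 3. Compound 3 is estimated at 20000 nM, with a range from 5000 nM to 80000 nM, and it is expected most likely to register only as a limit as well.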

Compound 3, half-maximal inhibitory concentration: > 10000 nM
Compound 3 was reported as a limit (the forecaster's own chance of this, stated with the estimate: 75%); the middle value lies beyond the limit too.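

No step from compound 1 to compound 3 can be read, since both values are limits and not numbers: the limit of > 10000 nM in this assay, at which 3 of the 3 values shown sit.
Going by these compounds, how far compound 1, compound 2 and compound 3 each lie beyond that limit in this assay stays open.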